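Chloro to hydrogen on compound 2

The source may hold more compounds than are shown below. What is called first, only, known or untested is meant among the compounds shown, and "the series" means these compounds.

In a functional assay on MV4-11 cells (Homo sapiens) for antiproliferative activity, read by CellTiter-Glo, with a stated time of 72 h (a lower number here means a stronger inhibitor of growth, a higher number a weaker inhibitor of growth), compound 1 (`COCC(=O)N[C@H]1CC[C@H](Nc2cc(-c3csc(NCC4CCOCC4)n3)c(Cl)cn2)CC1`) gives > 10000 nM as a limit of the assay and not a number. Compound 2 (`COCCN[C@H]1CC[C@H](Nc2cc(-c3csc(NCC4CCOCC4)n3)c(Cl)cn2)CC1`) gives 170 nM and stands within the scatter of compound 3 (`COC[C@@H](C)N[C@H]1CC[C@H](Nc2cc(-c3csc(NCC4CCOCC4)n3)c(Cl)cn2)CC1`) at 140 nM with a 1.2-fold lower number from compound 2 to compound 3 (0.08 log units; within the scatter) as the gap. Compound 4 (`COCCN[C@H]1CC[C@H](Nc2cc(-c3csc(NCC4CCOCC4)n3)ccn2)CC1`) carries hydrogen in place of chloro on an aromatic carbon. The measured steps reach only the group on the amine nitrogen: an at least 58-fold lower number from compound 1 to compound 2 (1.76 log units; beyond the scatter) and an at least 71-fold lower number from compound 1 to compound 3 (1.85 log units; beyond the scatter) are large but leave the chloro untouched, so neither sizes this change. A modest move to a higher number is expected, with wide margins. Estimated, this comes to a 2.1-fold higher number from compound 2 to compound 4 (0.31 log units; beyond the scatter) as the expected step. In this assay the estimate for compound 4 is 350 nM (expected range 100 nM to 1500 nM).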

Compound 4, concentration for 50% growth inhibition: 910 nM
The estimate for compound 4 lay 2.6-fold (0.41 log units) below the measured number; measured number inside the range.
By their numbers in this assay, from the lowest: compounds 3 and 2 (each within the scatter of the next); then compound 4. At a limit, above all of these: compound 1.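

In this assay, within the data shown here, hydrogen in place of chloro on this aromatic carbon gives a 5.4-fold higher number from compound 2 to compound 4 (0.73 log units; beyond the scatter) and is the first step read away from the amine nitrogen. With the 2-methoxyethyl group held constant, the position on the ring affects the number, and the chloro is favoured over hydrogen in this one pair.

Open, going by these compounds, is where fluoro, bromo, methyl or nitrile would fall at this position, and whether the chloro step carries over to the 1-(methoxymethyl)ethyl amine of compound 3. Nothing given here bears on why this step has its size.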